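Swapping the Sulfonyl for a Small Urea

The source may hold more compounds than are shown below. What is called first, only, known or untested is meant among the compounds shown, and "the series" means these compounds.

Compound 1 `CCOC(=O)N[C@@H](CCC(=O)N1CCN(c2cccc(NC3=NCCCN3)c2)CC1)C(=O)O` carries an ethoxycarbonyl on its amine nitrogen, and in a functional assay (muscle tissue) for inhibition, with Homo sapiens as the target (on this read-out lower numbers stand for stronger inhibition and higher numbers for weaker inhibition), compound 1 gives 2.1 nM. Compound 2 `Cc1cc(C)c(S(=O)(=O)N[C@@H](CCC(=O)N2CCN(c3cccc(NC4=NCCCN4)c3)CC2)C(=O)O)c(C)c1` has a (2,4,6-trimethylphenyl)sulfonyl there instead. In this assay compound 2 reaches only a limit, > 10 nM. That swap produced an at least 4.7-fold higher number from compound 1 to compound 2 (0.67 log units; beyond the scatter). Compound 3 `CCNC(=O)N[C@@H](CCC(=O)N1CCN(c2cccc(NC3=NCCCN3)c2)CC1)C(=O)O` undoes most of it: ethylcarbamoyl in place of (2,4,6-trimethylphenyl)sulfonyl on an amine nitrogen. Because the sulfonyl brought an at least 4.7-fold higher number from compound 1 to compound 2 (0.67 log units; beyond the scatter), its removal is expected to move the number back down, giving an estimated at least 3.3-fold lower number from compound 2 to compound 3 (0.52 log units; beyond the scatter). Compound 3 is therefore estimated at 3 nM, within 1 nM to 12 nM.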

Compound 3, half-maximal inhibitory concentration: > 10 nM
Compound 3: only a limit was reported (the forecaster's own chance of this, stated with the estimate: 5%); middle value at least 3.3-fold (0.52 log units) from the limit.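

Replacing ethoxy with ethylamino on a carbonyl carbon gives an at least 4.7-fold higher number from compound 1 to compound 3 (0.67 log units; beyond the scatter). At this amine nitrogen, then, a small ethylcarbamoyl does not match ethoxycarbonyl, so losing the (2,4,6-trimethylphenyl)sulfonyl is not enough on its own to bring the number back down. The step between compound 2 and compound 3 cannot be read because both compounds are reported only as the same limit: the limit of > 10 nM in this assay, at which 2 of the 3 values shown sit.

From the compounds shown here alone, the true value of compound 3 beyond that limit remains open. So does whether an acetyl on the amine nitrogen, or a propoxy on the carbonyl carbon, would keep the number close to that of compound 1.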